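Cytotoxicity notes on a methyl-to-ethyl step

A few compounds are considered here, and "the series" means these few. Any claim that something is new, unique, unknown or untested is made for them only; others in the source may bear on it.

Compound 1 `Cc1ccc2cc(CN(Cc3ccc(F)cc3)Cc3ccc(C(C)C)cc3)c(=O)[nH]c2c1` and compound 2 `CCc1ccc(CN(Cc2ccc(F)cc2)Cc2cc3ccc(C)cc3[nH]c2=O)cc1` share one core; compound 3 `Cc1ccc2cc(CN(Cc3ccc(C(C)(C)C)cc3)C3CCCC3)c(=O)[nH]c2c1` differs from compound 2 in more than one place, and the difference between the two cores is not broken down here. Compound 4 `CCc1ccc2cc(CN(Cc3ccc(C(C)(C)C)cc3)C3CCCC3)c(=O)[nH]c2c1` is not yet measured. In a toxicity assay on MDCK cells (Canis lupus familiaris) for cytotoxicity, read by crystal violet staining, with a stated time of 48 h (on this read-out lower numbers stand for higher toxicity in this test and higher numbers for lower toxicity in this test), compound 1 gives only a limit, > 33000 nM. Compound 2 likewise gives only a limit in this assay, > 33000 nM. Compound 3 gives only a limit in this assay, > 10000 nM. The change methyl in place of hydrogen on a saturated chain carbon bound to an aromatic carbon and a saturated chain carbon gives a step that the two limits leave unreadable from compound 2 to compound 1, both ends sitting at the limit of > 33000 nM in this assay, at which 2 of the 3 values shown sit. From compound 3 to compound 4 the change methyl in place of hydrogen on a saturated chain carbon bound to an aromatic carbon is the same kind of change, though here the carbon is bound to an aromatic carbon only, not also to a saturated chain carbon. Because compound 3 sits at the limit of > 10000 nM in this assay, at which 1 of the 3 values shown sits, compound 4 is expected to stay beyond a readable number; the expected step is a step that the limit leaves unreadable from compound 3 to compound 4. The estimate for compound 4 is 40000 nM.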

Compound 4, half-maximal cytotoxic concentration: > 9000 nM
Compound 4: no number, only a limit (the forecaster's own chance of this, stated with the estimate: 85%); the middle value is on the limit's open side.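

No new step can be read from compound 3 to compound 4: each gives only a limit, and the methyl to ethyl change has no readable size. The compounds shown leave open any actual half-maximal cytotoxic concentration.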